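The source may hold more compounds than are shown below. What is called first, only, known or untested is meant among the compounds shown, and "the series" means these compounds.

Compound 1 `Cn1cncc1CN1CC(N(CC2CCN(C(=O)C3CCCC3)CC2)S(=O)(=O)c2ccccn2)Cc2cc(C#N)ccc21` is one of three closely related compounds measured in an ADME assay on Caco-2 cells (Homo sapiens) for permeability, in the apical to basolateral direction; on this read-out lower numbers stand for lower permeability and higher numbers for higher permeability. In this assay compound 1 gives 0.5 10^-6 cm/s. Compound 2 `Cn1cncc1CN1CC(N(CC2CCN(C(=O)CC(C)(C)C)CC2)S(=O)(=O)c2ccccn2)Cc2cc(C#N)ccc21` gives 0.5 10^-6 cm/s in this assay, and compound 3 `Cn1cncc1CN1CC(N(CC2CCN(C(=O)N3CCCC3)CC2)S(=O)(=O)c2ccccn2)Cc2cc(C#N)ccc21` gives 0.6 10^-6 cm/s. Compound 1 thus stands level with compound 2 at the digits shown, and its distance to compound 3 is the largest among the three, yet that distance stays within the scatter.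

Compound 4 `CCOC(=O)N1CCC(CN(C2Cc3cc(C#N)ccc3N(Cc3cncn3C)C2)S(=O)(=O)c2ccccn2)CC1` is not yet measured. It differs from compound 1 by ethoxy in place of cyclopentyl on a carbonyl carbon. The measured steps that bear on this change are those made at the same carbonyl carbon: no change at the digits printed from compound 1 to compound 2 (within the scatter) and a 1.2-fold higher number from compound 1 to compound 3 (0.08 log units; within the scatter), with a 1.2-fold higher number from compound 2 to compound 3 (0.08 log units; within the scatter) between the two other compounds. None of these exchanges of the group on that carbonyl carbon moved the number in this assay beyond the scatter. On this basis no step beyond the scatter is expected from compound 1 to compound 4 either. Compound 4 is therefore expected to give 0.6 10^-6 cm/s in this assay, with a range from 0.3 10^-6 cm/s to 1.2 10^-6 cm/s. That estimate means an expected step of a 1.2-fold higher number from compound 1 to compound 4 (0.08 log units; within the scatter), a change that would lie within the scatter.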

Compound 4, apparent permeability: 2.6 10^-6 cm/s
Compound 4: middle estimate off by 4.3-fold (0.64 log units), on the low side; measured number above the stated range.
By their numbers in this assay, from the lowest: compounds 1, 2 and 3 (each within the scatter of the next); then compound 4.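

At the carbonyl carbon on the amide-type nitrogen in a ring, the group does matter in this assay: ethoxy gives a 5.2-fold higher number from compound 1 to compound 4 (0.72 log units; beyond the scatter) and a 5.2-fold higher number from compound 2 to compound 4 (0.72 log units; beyond the scatter) and also a 4.3-fold higher number from compound 3 to compound 4 (0.64 log units; beyond the scatter) even though cyclopentyl, neopentyl and pyrrolidin-1-yl had stayed within the scatter of one another. Among these four compounds, ethoxy is the only group that joins the carbonyl carbon through oxygen, whereas loss of the ring alone does not go with the higher number, as compound 2 also carries no ring on that carbon and stays level with compound 1. No measurement shown gives a reason for the step.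

Going by these compounds alone, with ethoxy as the only group of its kind here, the compounds leave open whether the higher number belongs to the oxygen link, to the small size of the group or to the two together. Methoxy, isopropoxy and tert-butoxy on the same carbonyl carbon would test the alkyl part, and an ethylamino group or a propyl chain there would test the oxygen link.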